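Dimethylamino to Propylamino on a Fused Tetrazine Core

The compounds below may be only part of what the source reports. "The series", "measured", "known", "first", "only" and "open" are said of these compounds alone.

Measured so far:
compound 1, `CN(C)c1nnc2nncn2n1` — 610 nM
compound 2, `CCC(=O)N1CCN(c2nnc3nncn3n2)CC1` — 13700 nM

Of the compounds shown here, two sharing the same core have been measured in a functional assay on BeWo cells (Homo sapiens) for inhibition, read by MTT assay, with a stated time of 72 h; a higher number here means a weaker inhibitor, a lower number a stronger inhibitor. Compound 1 gives 610 nM, the lowest of the two numbers, while compound 2 gives 13700 nM, a gap that lies beyond the scatter. Compound 3, `CCCNc1nnc2nncn2n1`, has not been measured. It differs from compound 1 in one place: propylamino in place of dimethylamino on an aromatic carbon. Within the data shown here, no step between measured compounds is available to calibrate this change, so the expectation rests on the standing of compound 1 alone. The step expected from compound 1 to compound 3 in this assay is small, of a size that may well lie within the scatter, with a slight lean toward a higher number, giving a 1.3-fold higher number from compound 1 to compound 3 (0.12 log units; within the scatter). Compound 3 is therefore estimated at 800 nM, within a range of 250 nM to 2500 nM.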

Compound 3, half-maximal inhibitory concentration: 14300 nM
Estimate against measurement, compound 3: 18-fold (1.25 log units) below; measured number outside the range, above it.
By their numbers in this assay, from the lowest: compound 1; then compounds 2 and 3 (each within the scatter of the next).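

In this assay, the group on this aromatic carbon, between two ring nitrogen atoms, proves far from interchangeable: the change to propylamino in place of dimethylamino gives a 23-fold higher number from compound 1 to compound 3 (1.37 log units; beyond the scatter). Among these compounds, the earlier compounds offered no step at this position, so this is the first sign that the number responds sharply here, even to a swap between two small amino groups that leaves the shared core untouched. Nothing measured here gives a reason for the size of this step.

As far as these compounds go, whether the higher number follows the hydrogen-bond donor or the longer chain stays open, for the two enter together in propylamino. From the compounds shown here alone, a methylamino or a diethylamino group on this carbon would separate those two changes, and how either would stand against compound 1 remains unknown.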